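From Isopropyl to Chloro: What Compound 4 Might Show

The compounds below may be only part of what the source reports. "The series", "measured", "known", "first", "only" and "open" are said of these compounds alone.

Compound 1, `CC(C)c1ccccc1NC(=O)N[C@H](C)c1ccccc1`, gives 103% in an ADME assay on the whole organism with Oryza sativa as the target, tested at 0.1 uM; a lower number here means a stronger effect, a higher number a weaker effect of the compound at the concentration tested.
Compound 2, `CC(C)c1ccccc1NC(=O)N[C@@H](C)c1ccccc1`, gives 99%.
Compound 3, `CCCCCCc1ccc(NC(=O)N[C@@H](C)c2ccccc2)cc1`, gives 99%.

Among these three numbers compound 1 stands highest, yet neither of the others lies beyond the scatter of it. The step of a number 4 percentage points lower from compound 1 to compound 2 (within the scatter) rests on (the fact that compounds 1 and 2 differ only in the configuration as drawn), and compound 3, which differs from compound 1 in more than one place, sits no further away than compound 2 does. The three measured values thus form a single tight cluster with nothing separating from the rest.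

Compound 4, `C[C@@H](NC(=O)Nc1ccccc1Cl)c1ccccc1`, is reached from compound 1 by one change: chloro in place of isopropyl on an aromatic carbon. For the measured compounds named here, no measured step touches this part of the molecule. Going by the values given here, the only single-point step in the set concerns configuration alone and stayed within the scatter, so it offers no guide to a swap of one aromatic substituent for another. With all three known values lying so close together, the data give no basis for expecting a move beyond the scatter in this assay in either direction.

Compound 4 is therefore expected to give about 100%, within a range from 90% to 110%. The expected step is a number 3 percentage points lower from compound 1 to compound 4 (within the scatter).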

Compound 4, a percentage reported as activity, at one concentration (the size of the read-out at that concentration, not a potency): 101%
For compound 4 the middle estimate is 1 percentage points below the measured one, within the range that was stated.
By their numbers in this assay, from the lowest: compounds 2, 3, 4 and 1 (each within the scatter of the next).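

In this assay the change of isopropyl to chloro gives a number 2 percentage points lower from compound 1 to compound 4 (within the scatter), and this is the only step shown that falls on an aromatic carbon ortho to a large group, a place that the step between the two configurations did not touch. For the compounds shown here, at this place, then, a group of 3 heavy atoms, all carbon, and a chloro group of 1 heavy atom cannot be told apart by this read-out at the concentration tested, so the tight cluster of the earlier compounds now holds across a change of substituent as well as a change of configuration. Going by these compounds alone, the one piece of evidence at hand concerns configuration alone and has no bearing on this swap of aromatic substituents.

Going by these compounds, what remains open is whether any group on this aromatic carbon can carry the number beyond the scatter, for instance an amine, a carboxylic acid or a longer chain in place of chloro. All four compounds lie within the scatter of one another in this assay, so the shown series contains no step large enough to show which parts of the shared core matter for this read-out.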